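The compounds below may be only part of what the source reports. "The series", "measured", "known", "first", "only" and "open" are said of these compounds alone.

Measured so far in a functional assay on isolated protein for inhibition of Glucose-dependent insulinotropic receptor (Rattus norvegicus), read by HTRF and cAMP accumulation; a lower number here means that less compound is needed, a higher number that more compound is needed for the effect:
compound 1 `Cc1nc(S(C)(=O)=O)ccc1Oc1ncnc(OC2CCN(C(=O)OC(C)C)CC2)c1F`: 142 nM
compound 2 `Cc1nc(S(C)(=O)=O)ccc1Oc1ncnc(OC2CCN(C(=O)OC3CCC3)CC2)c1F`: 167 nM
compound 3 `Cc1nc(S(C)(=O)=O)ccc1Oc1ncnc(OC2CCN(C(=O)OC(C)(C)C(F)(F)F)CC2)c1F`: 47.2 nM

Compound 3 stands lowest of the three in this assay: a 3.0-fold lower number from compound 1 to compound 3 (0.48 log units; beyond the scatter) and a 3.5-fold lower number from compound 2 to compound 3 (0.55 log units; beyond the scatter) both lie beyond the scatter, whereas a 1.2-fold higher number from compound 1 to compound 2 (0.07 log units; within the scatter) lies within it. Compound 4 `Cc1nc(S(C)(=O)=O)ccc1Oc1ncnc(OC2CCN(C(=O)OC(C)(C)C#N)CC2)c1F` differs from compound 3 by cyano in place of trifluoromethyl on a saturated chain carbon bound to an oxygen next to a carbonyl group and two saturated chain carbons. Going by the values given here, the steps that bear on this position are a 3.0-fold lower number from compound 1 to compound 3 (0.48 log units; beyond the scatter) and a 3.5-fold lower number from compound 2 to compound 3 (0.55 log units; beyond the scatter); both were modest and both describe the arrival of trifluoromethyl. Among the compounds with values here, no measured compound carries cyano there, so its effect has no direct precedent. For compound 4 a modest rise is expected, a 1.9-fold higher number from compound 3 to compound 4 (0.28 log units; within the scatter), possibly not beyond the scatter. Compound 4 is estimated at 90 nM in this assay, within 40 nM to 250 nM.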

Compound 4, half-maximal effective concentration: 1320 nM
Beside the measured number, compound 4's estimate is 15-fold (1.17 log units) below it; the measured number lies above the stated range.
By their numbers in this assay, from the lowest: compound 3; then compounds 1 and 2 (each within the scatter of the next); then compound 4.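

Going by these compounds alone, at the saturated chain carbon bound to an oxygen next to a carbonyl group and two saturated chain carbons, the choice of group carries far more weight in this assay than the earlier compounds showed: cyano in place of trifluoromethyl gives the largest step (a 28-fold higher number from compound 3 to compound 4 (1.45 log units; beyond the scatter)). Cyano also compares unfavourably with the isopropyl and cyclobutyl carbamates (a 9.3-fold higher number from compound 1 to compound 4 (0.97 log units; beyond the scatter); a 7.9-fold higher number from compound 2 to compound 4 (0.90 log units; beyond the scatter)), so the gain seen with trifluoromethyl does not carry over to it. No measurement bears on the reason for this difference.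

Going by these compounds, whether methyl, difluoromethyl or a longer chain at this carbon would track trifluoromethyl or cyano remains open.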